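From Pyrrolidinyl to Methylpiperazinyl: What Compound 4 May Give

The compounds below may be only part of what the source reports. "The series", "measured", "known", "first", "only" and "open" are said of these compounds alone.

Three compounds on one shared core were tested in a functional assay on HeLa cells (Homo sapiens) for antiproliferative activity, read by MTT assay, with a stated time of 72 h; a higher number here means a weaker inhibitor, a lower number a stronger inhibitor. Compound 1 `O=c1c(SC(=S)N2CCCC2)coc2ccc(Cl)cc12` gives 16300 nM and compound 2 `O=c1c(CSC(=S)N2CCN(c3ccccc3)CC2)coc2ccccc12` gives 7100 nM. Compound 3 `O=c1c(CSC(=S)N2CCCC2)coc2ccccc12` reaches only a limit of the assay, > 25000 nM. This is the limit of > 25000 nM in this assay, at which 1 of the 3 values shown sits, so for compound 3 no number is known, only that it sits at the limit. Compound 4 `CN1CCN(C(=S)SCc2coc3ccccc3c2=O)CC1` is not yet measured and differs from compound 3 in one place: 4-methylpiperazin-1-yl in place of pyrrolidin-1-yl on a thiocarbonyl carbon. For the measured compounds named here, no step between two measured compounds can be drawn from these data. Because compound 2 gives 7100 nM with another ring on the thiocarbonyl carbon, compound 4 is expected to fall inside the measured range, a step estimated as an at least 1.3-fold lower number from compound 3 to compound 4 (0.14 log units; that floor lies within the scatter). Compound 4 is estimated at 18000 nM, between 6000 nM and 60000 nM.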

Compound 4, half-maximal inhibitory concentration: 5900 nM
Beside the measured number, compound 4's estimate is 3.1-fold (0.48 log units) above it, and the stated range ends above it.
By their numbers in this assay, from the lowest: compounds 4 and 2 (each within the scatter of the next); then compound 1. At a limit, above all of these: compound 3.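

In this assay, 4-methylpiperazin-1-yl in place of pyrrolidin-1-yl on a thiocarbonyl carbon gives an at least 4.2-fold lower number from compound 3 to compound 4 (0.62 log units; beyond the scatter). Going by these compounds, compound 3 stands at a limit of the assay, so this step is a bound and its true size is unknown: the limit of > 25000 nM in this assay, at which 1 of the 4 values shown sits. Methyl in place of phenyl on an amine nitrogen in a ring gives a 1.2-fold lower number from compound 2 to compound 4 (0.08 log units; within the scatter), so this pair does not separate the two groups.

On these data alone, whether morpholin-4-yl on the thiocarbonyl carbon would give a number like that of compound 4 stays open. So does the effect of an acetyl group on the amine nitrogen in the ring.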